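This account rests on a few compounds, and the source may have more. Where it says the series, first, only, none or still open, it means among the compounds named here.

Three compounds on a shared core have been taken to a functional assay on A2780 cells (Homo sapiens) for antiproliferative activity, read by resazurin assay, with a stated time of 72 h (on this read-out higher numbers stand for weaker inhibition and lower numbers for stronger inhibition), and only one of them gave a number. Compound 1 `CCCN(C)C(=O)c1cc2c(Cc3ccccc3)n[nH]c2cc1O` gives > 10000 nM, which is a limit of the assay and not a number. For compound 2 `Cc1cccc(CN(C)C(=O)c2cc3c(Cc4ccccc4)n[nH]c3cc2O)c1` the entry reads "not determined" (no result reported). Among the measured compounds shown here, compound 3 `CN(Cc1ccc(F)cc1)C(=O)c1cc2c(Cc3ccccc3)n[nH]c2cc1O` gives 4100 nM, the only true number, so it cannot yet be ranked against a second measured value.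

Compound 4 `CCOc1ccc(CN(C)C(=O)c2cc3c(Cc4ccccc4)n[nH]c3cc2O)cc1` keeps everything in compound 3 except one group, with ethoxy in place of fluoro on an aromatic carbon, para to a large group: ethoxy in place of fluoro on an aromatic carbon.

For the measured compounds named here, only one measured step bears on this change, and only indirectly. It is an at least 2.4-fold lower number from compound 1 to compound 3 (0.38 log units; beyond the scatter), where 4-fluorophenyl replaces ethyl on a saturated chain carbon bound to an amide-type nitrogen. From the compounds shown here alone, its full size stays open given (the limit of > 10000 nM in this assay, at which 1 of the 3 values shown sits). Going by the values given here, no measured step alters the group that changes here, and compound 4 retains the aromatic ring gained in that step, so its value is expected to stay near that of compound 3 at 4100 nM.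

The estimated change is a 1.2-fold lower number from compound 3 to compound 4 (0.07 log units; within the scatter), so no step beyond the scatter is expected in this assay. For compound 4 the expected value is 3500 nM, with an estimated range from 1200 nM to 10000 nM.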

Compound 4, half-maximal inhibitory concentration: 3200 nM
For compound 4 the middle estimate is 1.1-fold (0.04 log units) above the measured one, within the range that was stated.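

Among the compounds shown here, compound 4 gives the first direct reading of a change on the aromatic ring itself. In this assay, putting ethoxy in place of fluoro on this aromatic carbon, para to a large group, gives a 1.3-fold lower number from compound 3 to compound 4 (0.11 log units; within the scatter), so on this read-out the position accepts 3 heavy atoms and 1 hydrogen-bond acceptor where fluoro stood, with no change that can be told from the scatter. Compound 4 also shows that the separation from compound 1 seen with the 4-fluorobenzyl group of compound 3 is kept with the 4-ethoxybenzyl group, at an at least 3.1-fold lower number from compound 1 to compound 4 (0.49 log units; beyond the scatter), although the value for compound 1 is a limit of the assay and not a number, so the full size of this step stays open: the limit of > 10000 nM in this assay, at which 1 of the 4 values shown sits.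

From the compounds shown here alone, with only fluoro and ethoxy read at this position, it remains open whether an amine, a carboxylic acid or a longer alkoxy chain there would move the number beyond the scatter. Also open, going by these compounds, is how the number would respond to a change elsewhere on the molecule, such as replacing the benzyl group on the shared core with a pyridylmethyl group.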